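The source may hold more compounds than are shown below. What is called first, only, known or untested is meant among the compounds shown, and "the series" means these compounds.

Measured so far in a physicochemical assay for solubility, read by HPLC, in phosphate buffer, with a stated time of 24 h, at pH 7.4, tested at 100 uM; on this read-out lower numbers stand for lower solubility and higher numbers for higher solubility:
compound 1 (`Cc1ccc(Nc2c(NCCCCCC(=O)NO)c(=O)c2=O)cc1`) gives 8100000 nM
compound 2 (`COc1ccc(Nc2c(NCCCCCC(=O)NO)c(=O)c2=O)cc1`) gives 3300000 nM

Compound 2 holds the lower of these two numbers, and its gap to compound 1 lies beyond the scatter. The next compound, compound 3 (`O=C(CCCCCNc1c(Nc2ccc(C(F)(F)F)cc2)c(=O)c1=O)NO`), keeps the shared core and has trifluoromethyl in place of methoxy on an aromatic carbon, para to a large group (trifluoromethyl in place of methoxy on an aromatic carbon). Among the compounds with values here, only one measured step bears on this change, a modest one at the same aromatic carbon, where methoxy replaced methyl: a 2.5-fold lower number from compound 1 to compound 2 (0.39 log units; beyond the scatter) (the sole guide to step size here). Neither measured compound carries trifluoromethyl, so this step gives a scale and not a direct precedent. A step of similar modest size is therefore expected in this assay, toward a lower number, and the direction remains a judgement resting on very little data. The expected step is a 2.2-fold lower number from compound 2 to compound 3 (0.34 log units; beyond the scatter) (an estimate). Compound 3 is expected at 1500000 nM (estimated range 400000 nM to 5000000 nM).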

Compound 3, solubility: 4500000 nM
The estimate for compound 3 lay 3.0-fold (0.48 log units) below the measured number; low and high end bracket the measured number.
By their numbers in this assay, from the lowest: compounds 2, 3 and 1 (each within the scatter of the next, the first and the last beyond it).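

Notes on the aromatic carbon para to a large group: in this assay, trifluoromethyl in place of methoxy, which takes 2 heavy atoms and 1 hydrogen-bond acceptor out and puts 4 heavy atoms and 0 hydrogen-bond acceptors in, gives a step that stays within the scatter (a 1.4-fold higher number from compound 2 to compound 3 (0.13 log units; within the scatter)). Trifluoromethyl in place of methyl also stays within the scatter (a 1.8-fold lower number from compound 1 to compound 3 (0.26 log units; within the scatter)), so compound 3 cannot be told apart from either compound 1 or compound 2, although those two remain apart (a 2.5-fold lower number from compound 1 to compound 2 (0.39 log units; beyond the scatter)). No measurement is available that bears on a cause for this result.

As far as these compounds go, with only methyl, methoxy and trifluoromethyl at this carbon, it remains open how far this assay would move with an amine or a carboxylic acid there, and whether any group at this carbon gives a step larger than the modest one seen so far. Also open, from the compounds shown here alone, is whether the same three groups would read the same way on a longer chain in place of the one shared by all three compounds.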